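The source may hold more compounds than are shown below. What is called first, only, known or untested is meant among the compounds shown, and "the series" means these compounds.

Two compounds built on the core of compound 1 `O=C(Nc1ccc(NC(=O)c2cnc3ccccc3n2)cc1)c1ccccc1` have so far been measured in a functional assay on ileum for antagonist activity at 5-hydroxytryptamine receptor 3A (Cavia porcellus); a higher number here means weaker binding, a lower number tighter binding. Compound 1 gives 12600 nM, the highest of the two numbers. Compound 2 `O=C(NC1CCCC1)c1cnc2ccccc2n1`, in which the amide carries a cyclopentyl group, gives 316 nM, a gap that lies well beyond the usual scatter. Compound 3 `COc1ccc(NC(=O)c2cnc3ccccc3n2)cc1` differs from compound 1 in one place: methoxy in place of benzamido on an aromatic carbon. Among the compounds with values here, no measured pair shows this particular change, so its size rests on inference alone. The tighter binding of compound 2 at 316 nM against compound 1 at 12600 nM suggests that a smaller substituent on the core is tolerated well. From compound 1 to compound 3 the number is therefore expected to fall beyond the scatter, by a step of about a 5.0-fold lower number from compound 1 to compound 3 (0.70 log units; beyond the scatter). Compound 3 is estimated at 2500 nM, with a range from 600 nM to 10000 nM.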

Compound 3, dissociation constant: 10000 nM
Compound 3: the middle estimate sits 4.0-fold (0.60 log units) below what was measured; low and high end bracket the measured number.
By their numbers in this assay, from the lowest: compound 2; then compounds 3 and 1 (each within the scatter of the next).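

In this assay, methoxy in place of benzamido on the aromatic carbon gives a 1.3-fold lower number from compound 1 to compound 3 (0.10 log units; within the scatter), so at this position, para to a large group, the two groups cannot be told apart. Benzamido carries a six-membered aromatic ring and a hydrogen-bond donor that methoxy lacks, yet losing them leaves the number within the scatter, which the earlier compounds could not show. No measured evidence on the cause of this result is available.

Going by these compounds, it remains open whether another group at this position, such as an amine, a carboxylic acid or a longer alkoxy chain, would move the number beyond the scatter. Within the data shown here, no single-place step links compound 2 to the other compounds, so what a cyclopentyl group does on the amide, compared with a cyclohexyl group or a smaller chain, also stays open.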